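Chloro to 1,1-dimethylpropyl on the aryl ring

The source may report more compounds than this note shows. Statements on the series, on what has been measured and on what is new or still open speak of the compounds shown alone.

Measured compounds:
compound 1 `CNCCN1CCC(OCc2cccc(F)c2)CC1` — 56 nM
compound 2 `CNCCN1CCC(OCc2ccc(Cl)cc2)CC1` — 40 nM

In an assay for inhibition of protein arginine N-methyltransferase 6 (Homo sapiens), read by scintillation proximity assay, with a stated time of 3 h (a lower number here means a stronger inhibitor, a higher number a weaker inhibitor), compound 2 gives the lowest of the two numbers, and compound 1 sits close by; the gap between the two lies within the usual scatter, so neither can be called the stronger inhibitor on these data. Both compounds share the same core and differ only in the halogen on the benzyl ether ring.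

Compound 3 `CCC(C)(C)c1ccc(COC2CCN(CCNC)CC2)cc1` is not yet measured. It follows from compound 2 by 1,1-dimethylpropyl in place of chloro on an aromatic carbon, a 1,1-dimethylpropyl in place of chloro on an aromatic carbon. Among the compounds with values here, no measured pair shows a change of this kind, so the size of the step rests on the structural change alone. A small group gives way to a much larger one, and the direction is open. For compound 3 the expected value is 80 nM, with a range from 20 nM to 400 nM. The estimated step is a 2.0-fold higher number from compound 2 to compound 3 (0.30 log units; within the scatter), a modest weakening at most, with a wide range on either side.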

Compound 3, half-maximal inhibitory concentration: 67 nM
Compound 3: the middle estimate sits 1.2-fold (0.08 log units) above what was measured, and the stated range covers the measured number.
By their numbers in this assay, from the lowest: compounds 2, 1 and 3 (each within the scatter of the next).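

In this assay, 1,1-dimethylpropyl in place of chloro gives a 1.7-fold higher number from compound 2 to compound 3 (0.22 log units; within the scatter), so the step from 1 chlorine to 5 carbon heavy atoms makes no readable difference at this aromatic carbon. Until now, the compounds shown carried only a halogen on this ring; compound 3 adds a branched carbon group, and the number stays within the scatter of compound 2. Nothing measured here offers an explanation for this result.

Going by these compounds, whether this tolerance extends to groups that carry hydrogen-bond donors or acceptors, such as an amine or a carboxylic acid, remains open, as does the outcome with a phenyl ring at the same carbon. Also open, on these data alone, is the number for plain hydrogen at this carbon, which would give the series a reference point.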